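A few compounds are considered here, and "the series" means these few. Any claim that something is new, unique, unknown or untested is made for them only; others in the source may bear on it.

Of the compounds shown here, two built on one shared core have been measured in an assay for binding affinity to histone acetyltransferase KAT2B (Homo sapiens), read by HTRF, with a stated time of 15 h; a lower number here means a stronger inhibitor, a higher number a weaker inhibitor. Compound 1, `CN1C[C@H](Nc2nc3cc[nH]c3c(=O)n2C)C[C@H](c2cccc(Br)c2)C1`, carries a bromine-bearing aromatic ring, and in this assay compound 1 gives 22 nM. Compound 2, `CN1C[C@H](Nc2nc3cc[nH]c3c(=O)n2C)C[C@H](c2ccc(OC(F)(F)F)cc2)C1`, instead carries an aromatic ring bearing trifluoromethoxy, and in this assay compound 2 gives 17 nM. Compound 2 thus has the lowest of the two numbers, but the gap to compound 1 lies within the scatter of the method, so the two cannot be told apart.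

Compound 3, `CN1C[C@H](Nc2nc3cc[nH]c3c(=O)n2C)C[C@H](c2ccc(O)cc2)C1`, has not yet been measured. The change from compound 2 to compound 3 is hydrogen in place of trifluoromethyl on an oxygen on an aromatic ring; cut one bond further out, it reads trifluoromethoxy to hydroxy. For the measured compounds named here, no measured pair shows this change, so its effect is not known from the numbers at hand. Because compound 1 at 22 nM and compound 2 at 17 nM lie within the scatter of each other despite different groups on that ring, only a modest step is expected. A small loss in this assay is expected, a step of a 2.4-fold higher number from compound 2 to compound 3 (0.37 log units; beyond the scatter). Compound 3 is therefore estimated at 40 nM, in a range from 10 nM to 160 nM.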

Compound 3, half-maximal inhibitory concentration: 30 nM
Compound 3: the middle estimate sits 1.3-fold (0.12 log units) above what was measured; low and high end bracket the measured number.
By their numbers in this assay, from the lowest: compounds 2, 1 and 3 (each within the scatter of the next).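

For the compounds shown here, the step of a 1.8-fold higher number from compound 2 to compound 3 (0.25 log units; within the scatter) in this assay gives the first reading of a change on the oxygen itself: trifluoromethyl, with its 4 heavy atoms, gives way to a single hydrogen, and the numbers stay within the usual scatter of each other. The step of a 1.4-fold higher number from compound 1 to compound 3 (0.13 log units; within the scatter) has 4-hydroxyphenyl in place of 3-bromophenyl on a saturated ring carbon, and it too stays within the scatter. The earlier pair showed this only for the bromine-bearing and trifluoromethoxy-bearing rings, whereas the three compounds now show that a ring bearing hydroxy also cannot be told apart from either of them.

On these data alone, whether an amine or a carboxylic acid on that aromatic ring would give a step beyond the scatter remains open. Also open, as far as these compounds go, is how methoxy or a longer chain on the same oxygen, such as ethoxy, would compare with the hydroxy of compound 3.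

No other measurement bears on these results, and what lies behind the numbers stays unexplained.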